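A new group on the sulfonyl sulfur

The source may report more compounds than this note shows. Statements on the series, on what has been measured and on what is new or still open speak of the compounds shown alone.

Values in a functional assay on HeLa cells (Homo sapiens) for antiproliferative activity, read by MTT assay, with a stated time of 72 h; a higher number here means a weaker inhibitor, a lower number a stronger inhibitor:
Compound 1 `N=C(NS(=O)(=O)c1ccccc1Cl)N1CCN(c2cc3c(cc2F)c(=O)c(C(=O)O)cn3C2CC2)CC1` gives 32 nM
Compound 2 `N=C(NS(=O)(=O)c1ccc(Cl)cc1)N1CCN(c2cc3c(cc2F)c(=O)c(C(=O)O)cn3C2CC2)CC1` gives 32 nM

Level with compound 1 at the digits shown stands compound 2 at 32 nM. The next compound to be tested, compound 3 `N=C(NS(=O)(=O)c1ccccc1C(F)(F)F)N1CCN(c2cc3c(cc2F)c(=O)c(C(=O)O)cn3C2CC2)CC1`, differs from it in one place: 2-(trifluoromethyl)phenyl in place of 4-chlorophenyl on a sulfonyl sulfur. In words, 2-(trifluoromethyl)phenyl comes in place of 4-chlorophenyl on a sulfonyl sulfur.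

For the measured compounds named here, only one measured step bears on this change. The step of no change at the digits printed from compound 1 to compound 2 (within the scatter) exchanges 2-chlorophenyl for 4-chlorophenyl on the same sulfur, and its size lies within the scatter of repeated measurements. That step is a limited guide, since neither measured compound carries a trifluoromethyl group. The two values therefore support no direction for the new change, and the range has to stay wide. The estimated step is a 1.1-fold higher number from compound 2 to compound 3 (0.04 log units; within the scatter), and it is expected to stay within the scatter. For compound 3 the expected value in this assay is an estimated 35 nM, with a range from 12 nM to 100 nM.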

Compound 3, half-maximal inhibitory concentration: 32 nM
Estimate against measurement, compound 3: 1.1-fold (0.04 log units) above; the range from low to high includes it.
By their numbers in this assay, from the lowest: compounds 1, 2 and 3 (each within the scatter of the next).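

In this assay, a ring with 10 heavy atoms, 2-(trifluoromethyl)phenyl, takes the place of 4-chlorophenyl with its 7 heavy atoms on the sulfonyl sulfur, and the values do not separate (no change at the digits printed from compound 2 to compound 3 (within the scatter)). The earlier step only exchanged 2-chlorophenyl for 4-chlorophenyl, whereas this series now also shows a different group on the ring: trifluoromethyl in place of chloro on an aromatic carbon also gives no readable difference (no change at the digits printed from compound 1 to compound 3 (within the scatter)). So, in this assay, the three aryl groups on this sulfur cannot be told apart, although no accompanying measurement explains why.

All three compounds carry a benzene ring on this sulfur with a single chloro or trifluoromethyl group, so they say little about how far this tolerance extends. An amine or a carboxylic acid on that ring, or a plain alkyl chain in place of the ring, could behave quite differently, and these three values give no way of telling.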